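Methoxy in place of vinyloxy on the shared core

This account rests on a few compounds, and the source may have more. Where it says the series, first, only, none or still open, it means among the compounds named here.

Compound 3 `C=COc1ccccc1OC(C)C1=NCCN1` gives the highest number of the three measured, 631 nM in a functional assay on CHO cells for agonist activity at Alpha-2C adrenergic receptor (Homo sapiens); a higher number here means that more compound is needed for the effect, a lower number that less compound is needed. Compound 1 `C=C(C)c1ccccc1OC(C)C1=NCCN1` gives 115 nM and compound 2 `CC(C)Oc1ccccc1OC(C)C1=NCCN1` gives 100 nM. Compound 4 `COc1ccccc1OC(C)C1=NCCN1` differs from compound 3 by methyl in place of vinyl on an oxygen on an aromatic ring. The step that bears most directly on it is a 6.3-fold higher number from compound 2 to compound 3 (0.80 log units; beyond the scatter), where a saturated group on that oxygen gave the lower number; a 5.5-fold higher number from compound 1 to compound 3 (0.74 log units; beyond the scatter) points the same way, and a 1.2-fold lower number from compound 1 to compound 2 (0.06 log units; within the scatter) shows that two saturated groups at this position sit within the scatter of each other. Returning to a saturated group on the oxygen is therefore expected to give a lower number, a 4.2-fold lower number from compound 3 to compound 4 (0.62 log units; beyond the scatter). Compound 4 is estimated at 150 nM, with a range from 50 nM to 500 nM.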

Compound 4, half-maximal effective concentration: 9770 nM
Estimate against measurement, compound 4: 65-fold (1.81 log units) below, outside the stated range (above it).
By their numbers in this assay, from the lowest: compounds 2 and 1 (each within the scatter of the next); then compound 3; then compound 4.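

At this position, on an oxygen on an aromatic ring, a saturated group does not by itself give the lower number: methyl in place of vinyl gives (a 15-fold higher number from compound 3 to compound 4 (1.19 log units; beyond the scatter)) and methyl in place of isopropyl gives (a 98-fold higher number from compound 2 to compound 4 (1.99 log units; beyond the scatter)). Methoxy in place of 1-methylethenyl gives (an 85-fold higher number from compound 1 to compound 4 (1.93 log units; beyond the scatter)), so vinyloxy, isopropoxy and 1-methylethenyl all give lower numbers than methoxy, and no compound shown goes against this. Nothing shown gives a reason for these steps.

As far as these compounds go, whether ethoxy or a longer chain such as propoxy recovers the lower number remains open. So does the outcome with an amine at this place.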